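Three Limits and One Methyl on the Chain

The source may hold more compounds than are shown below. What is called first, only, known or untested is meant among the compounds shown, and "the series" means these compounds.

Compound 1 `COC(=O)N(C)CC#CCn1cncc1C`: in a functional assay on the whole organism for agonist activity, with Mus musculus as the target (a higher number here means that more compound is needed for the effect, a lower number that less compound is needed), compound 1 gives > 100 mg/kg, a limit of the assay rather than a number.
Compound 2 `CCOC(=O)N(C)CC#CCN1CCCC1`: in this assay compound 2 gives > 100 mg/kg, likewise a limit.
Compound 3 `CCOC(=O)N(C)CC#CCn1cncc1C`: in this assay compound 3 gives > 100 mg/kg, likewise a limit.

From compound 1 to compound 3 the change is methyl in place of hydrogen on a saturated chain carbon bound to an oxygen next to a carbonyl group. The step it made, a step that the two limits leave unreadable from compound 1 to compound 3, cannot be read because of the limit of > 100 mg/kg in this assay, at which 3 of the 3 values shown sit. Compound 4 `CCOC(=O)N(C)C(C)C#CCN1CCCC1` is not yet measured and differs from compound 2 by methyl in place of hydrogen on a saturated chain carbon bound to an amide-type nitrogen and a triple-bonded carbon. This is the same kind of change, but the place differs: in compound 3 the carbon is bound to an oxygen next to a carbonyl group, in compound 4 to an amide-type nitrogen and a triple-bonded carbon. How the core of compound 2 differs from the core of compound 1 is not broken down here. The step from compound 2 to compound 4 is expected to be small, a step that the limit leaves unreadable from compound 2 to compound 4, since (the limit of > 100 mg/kg in this assay, at which 3 of the 3 values shown sit). Compound 4 is therefore estimated at about 150 mg/kg, most likely reported again only as a limit.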

Compound 4, dose for half-maximal effect: > 100 mg/kg
Compound 4: no number, only a limit; the forecaster's own chance of this, stated with the estimate: 80%; the middle value is on the limit's open side.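

In this assay compound 4 gives > 100 mg/kg, again a limit and not a number. The step from compound 2 to compound 4 therefore cannot be read: the limit of > 100 mg/kg in this assay, at which 4 of the 4 values shown sit.

The compounds shown leave open what dose any of them needs, and whether either added methyl changes that dose.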